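The source may report more compounds than this note shows. Statements on the series, on what has been measured and on what is new or still open speak of the compounds shown alone.

On these data alone, the study takes in three measured ureas and one that is still open. Compound 1 `C[C@@H](NC(=O)Nc1ccccc1F)c1ccccc1` gives 77% in an ADME assay on the whole organism with Oryza sativa as the target, tested at 10 uM; on this read-out higher numbers stand for a weaker effect at the one concentration tested and lower numbers for a stronger effect. Compound 2 `C[C@H](NC(=O)Nc1ccc(F)cc1)c1ccccc1` gives 85% in this assay; the difference between the core of compound 1 and the core of compound 2 is not broken down here, and their two numbers lie within the usual scatter of each other. Compound 3 `C[C@H](NC(=O)Nc1ccc(F)cc1F)c1ccccc1` gives 99% in this assay. Compound 3 arises from compound 2 by fluoro in place of hydrogen on an aromatic carbon, and that single change brings a number 14 percentage points higher from compound 2 to compound 3 (beyond the scatter). The gap from compound 1 to compound 3 is also beyond the scatter, so compound 3 stands apart from both of the others.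

Compound 4 `C[C@@H](NC(=O)Nc1c(F)cccc1F)c1ccccc1` has not yet been measured. It arises from compound 1 by fluoro in place of hydrogen on an aromatic carbon, the same change as that between compound 2 and compound 3, made at a place described in the same words. Because a number 14 percentage points higher from compound 2 to compound 3 (beyond the scatter) was seen once already, a step of a number 14 percentage points higher from compound 1 to compound 4 (beyond the scatter) is expected in this assay. Compound 4 is therefore estimated at 91%, with a range from 80% to 100%.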

Compound 4, a percentage reported as activity, at one concentration (the size of the read-out at that concentration, not a potency): 98%
The estimate for compound 4 lay 7 percentage points below the measured number, within the range that was stated.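

In this assay the added fluoro on the core of compound 1 gives a number 21 percentage points higher from compound 1 to compound 4 (beyond the scatter), a step in the same direction as the one seen on the other core, towards a weaker effect at the one concentration tested. The two steps do not differ by more than repeated measurements of this kind would allow: the same change on two cores in this assay, a number 14 percentage points higher (beyond the scatter) from compound 2 to compound 3 and a number 21 percentage points higher (beyond the scatter) from compound 1 to compound 4, 7 percentage points apart, within the scatter of two such steps. In this small series the change therefore carried from one core to the other with its direction kept and no size difference that can be told apart, but two cores are too few to show that it would carry to any further core, and these numbers do not say why the step occurs.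

The compounds shown leave open whether a chloro or a methyl group in place of the hydrogen would bring a step of this kind. They also leave open how the numbers would respond to an amine, a carboxylic acid or a longer chain on the shared core.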